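Adding a Cyclopropylmethyl Group to Compound 2

This account rests on a few compounds, and the source may have more. Where it says the series, first, only, none or still open, it means among the compounds named here.

Compound 1 `C[C@H](Oc1ccc2ncc(/C=C/C(N)=O)c(C3CC3)c2c1)c1c(Cl)ccc(F)c1Cl`: > 5.5 in a physicochemical assay for lipophilicity, using the shake flask method (a higher number here means a more lipophilic compound, a lower number a more polar compound), a limit of the assay rather than a number
Compound 2 `C[C@H](Oc1ccc(/C=C/C(=O)O)cc1)c1c(Cl)ccc(F)c1Cl`: 2.8
Compound 3 `C[C@H](Oc1ccc2ncc(/C=C/C(=O)O)c(-n3ccnc3)c2c1)c1c(Cl)ccc(F)c1Cl`: 2

Of the two numbers in this assay, compound 2 stands highest, and compound 3 lies lower by a gap beyond the usual scatter. Compound 4 `C[C@H](Oc1ccc(/C=C/C(=O)O)c(CC2CC2)c1)c1c(Cl)ccc(F)c1Cl` is not yet measured. It differs from compound 2 in one place: cyclopropylmethyl in place of hydrogen on an aromatic carbon.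

Within the data shown here, no measured pair in this set shows a change of this kind, so its size must be guessed. The group that enters carries only carbon, so the step from compound 2 to compound 4 is expected to go upward, by a number 1.20 log units higher from compound 2 to compound 4 (beyond the scatter). Compound 4 is therefore expected to give about 4, somewhere between 3.3 and 4.7.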

Compound 4, distribution coefficient: 3.9
The estimate for compound 4 lay 0.10 log units above the measured number; the measured number falls inside the stated range.
By their numbers in this assay, from the lowest: compound 3; then compound 2; then compound 4. At a limit, above all of these: compound 1.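

Among these compounds, this is the first change in one place in the set, so it gives a first measured size for such a step: cyclopropylmethyl in place of hydrogen on an aromatic carbon, ortho to a 2-carboxyethenyl group, gives in this assay a number 1.10 log units higher from compound 2 to compound 4 (beyond the scatter). Even with this carbon-only group, compound 4 still gives a number rather than a limit, so the reading stays within the assay's range: the limit of > 5.5 in this assay, at which 1 of the 4 values shown sits.

Going by these compounds, whether methyl or an amine at this position would give a step of similar size remains open, as does the step for cyclopropylmethyl on another aromatic carbon.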